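The source may hold more compounds than are shown below. What is called first, only, known or untested is meant among the compounds shown, and "the series" means these compounds.

Measured compounds:
Compound 1 `CC(=O)N1c2ccccc2CCC1C(=O)Nc1ccccc1O` — 49700 nM in a functional assay on NUGC-3 cells (Homo sapiens) for cytotoxicity, read by sulforhodamine B assay, with a stated time of 72 h; a lower number here means a stronger inhibitor of growth, a higher number a weaker inhibitor of growth
Compound 2 `O=C(Nc1ccc(C(F)(F)F)cc1)C1CCc2ccccc2N1` — 18600 nM in this assay
Compound 3 `CC(=O)N1c2ccccc2CCC1C(=O)Nc1cc(C(F)(F)F)cc(C(F)(F)F)c1` — > 70000 nM in this assay

Going by the values given here, compound 3 stands at the weak end of what has been measured: its value in this assay is a limit of the assay and not a number, and the limit of > 70000 nM in this assay, at which 1 of the 3 values shown sits, records it as the one value sitting there. Compound 4 `CCCCCCCCC(=O)N1c2ccccc2CCC1C(=O)Nc1cc(C(F)(F)F)cc(C(F)(F)F)c1` differs from compound 3 by heptyl in place of hydrogen on a saturated chain carbon bound to a carbonyl carbon. Among the compounds with values here, no measured pair shows what such a change does here, so no size or direction beyond the scatter can be read from the data, and the step in this assay is expected to be small. Compound 4 is estimated at 70000 nM, with a range from 20000 nM to 200000 nM. The expected step from compound 3 to compound 4 is a number no higher from compound 3 to compound 4 (the limit leaves the size open).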

Compound 4, concentration for 50% growth inhibition: 2230 nM
Compound 4: the middle estimate sits 31-fold (1.50 log units) above what was measured; measured number below the stated range.
By their numbers in this assay, from the lowest: compound 4; then compound 2; then compound 1. At a limit, above all of these: compound 3.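

In this assay, the saturated chain carbon bound to the carbonyl carbon proves to be a place where a change counts, with heptyl in place of hydrogen giving an at least 31-fold lower number from compound 3 to compound 4 (1.49 log units; beyond the scatter). The earlier compounds shown here offered no step at this position, or at any other. Compound 3 is recorded only as a limit, so the full size of the step stays open because of that limit: the limit of > 70000 nM in this assay, at which 1 of the 4 values shown sits.

Going by these compounds, whether a shorter chain, a longer chain or a chain ending in an amine or a carboxylic acid would act alike remains open. So does whether heptyl would have the same effect on compound 1.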